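A few compounds are considered here, and "the series" means these few. Any claim that something is new, unique, unknown or untested is made for them only; others in the source may bear on it.

Measured so far in a functional assay on HeLa cells (Homo sapiens) for antiproliferative activity, read by sulforhodamine B assay, with a stated time of 72 h; on this read-out higher numbers stand for weaker inhibition and lower numbers for stronger inhibition:
- compound 1 `COc1ccc(C)cc1NC(=S)N/N=C/c1ccc2ccccc2n1` — > 100000 nM
- compound 2 `CC(C)c1cccc(C(C)C)c1NC(=S)N/N=C/c1ccc2ccccc2n1` — 16400 nM
- compound 3 `NC(=S)N/N=C/c1ccc2cccnc2n1` — > 100000 nM

The value for compound 1 in this assay, > 100000 nM, is a limit of the assay and not a number. The value for compound 3, > 100000 nM, is likewise a limit. Only compound 2 returns a number in this assay, 16400 nM. Among the compounds with values here, compound 1 thus stands at the upper edge of what the assay reports, together with compound 3, as noted in the limit of > 100000 nM in this assay, at which 2 of the 3 values shown sit; no step between two measured compounds that differ in a single place is available, so the size of any single change is not yet known from measurement.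

Compound 4 `COc1ccccc1NC(=S)N/N=C/c1ccc2ccccc2n1` is not yet measured. It differs from compound 1 by hydrogen in place of methyl on an aromatic carbon.

With compound 1 already at the limit, the step from compound 1 to compound 4 is expected to be small or none beyond the scatter, and the assay is likely to report a limit again for compound 4, as estimated by a step that the limit leaves unreadable from compound 1 to compound 4. Compound 4 is therefore expected to give about 150000 nM in this assay, with a range from 40000 nM to 500000 nM.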

Compound 4, half-maximal inhibitory concentration: > 100000 nM
Compound 4: only a limit was reported (the forecaster's own chance of this, stated with the estimate: 70%); the middle value is on the limit's open side.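

In this assay compound 4 gives > 100000 nM, a limit and not a number. Compound 1 is also a limit, so the step between compound 1 and compound 4 cannot be read: the limit of > 100000 nM in this assay, at which 3 of the 4 values shown sit.

The compounds shown leave open whether hydrogen in place of methyl on an aromatic carbon changes the read-out at all.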